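Adding a Second Chloro Group: Cytotoxicity in Kidney Cells

The source may report more compounds than this note shows. Statements on the series, on what has been measured and on what is new or still open speak of the compounds shown alone.

Compound 1 `C=C[C@@](C)(/C=C/c1ccc(O)c(/C=C/c2ccc(Cl)cc2)c1)CCC=C(C)C` and compound 2 `C=C[C@@](C)(/C=C/c1ccc(O)c(/C=C/c2ccc(Cl)c(Cl)c2)c1)CCC=C(C)C` share one core, while compound 3 `C=C[C@@](C)(/C=C/c1ccc(Nc2ccc(Cl)cc2)cc1)CCC=C(C)C` and compound 4 `C=C[C@@](C)(/C=C/c1ccc(Nc2ccc(Cl)c(Cl)c2)cc1)CCC=C(C)C` share another; how the two cores differ is not broken down here. In an ADME assay on HEK293 cells (Homo sapiens) for cytotoxicity, with a stated time of 72 h (on this read-out higher numbers stand for an effect only at larger amounts of compound and lower numbers for an effect already at smaller amounts), compound 1 gives only a limit, > 36600 nM. Compound 2 likewise gives only a limit, > 36600 nM. Compound 3 also gives only a limit, > 36600 nM. The change from compound 1 to compound 2 is chloro in place of hydrogen on an aromatic carbon, and the step it made is a step that the two limits leave unreadable from compound 1 to compound 2 because of the limit of > 36600 nM in this assay, at which 3 of the 3 values shown sit. The change from compound 3 to compound 4 is the same one, (chloro in place of hydrogen on an aromatic carbon). The step expected from this change is a step that the limit leaves unreadable from compound 3 to compound 4, since the limit of > 36600 nM in this assay, at which 3 of the 3 values shown sit, leaves no room for a readable step. Compound 4 is therefore estimated at 50000 nM in this assay.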

Compound 4, half-maximal effective concentration: > 36600 nM
Compound 4 gave a limit, no number (the forecaster's own chance of this, stated with the estimate: 85%); the middle value lies beyond the limit too.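

No step can be read from compound 3 to compound 4 in this assay, because both compounds give only a limit: the limit of > 36600 nM in this assay, at which 4 of the 4 values shown sit. Going by these compounds, whether the second chloro group changes cytotoxicity on either core remains open.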